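The source may report more compounds than this note shows. Statements on the series, on what has been measured and on what is new or still open speak of the compounds shown alone.

Compound 1 `CC(CCc1ccc(OCc2ccc3ccccc3n2)cc1)Cc1nnn[nH]1` gives 20 nM
Compound 2 `O=C(O)CCCOc1ccc(OCc2ccc3ccccc3n2)cc1` gives 800 nM

In a functional assay (lung) for inhibition, with Cavia porcellus as the target (a lower number here means a stronger inhibitor, a higher number a weaker inhibitor), compound 2 has the higher number of the two at 800 nM and lies beyond the scatter from compound 1. Within the data shown here, compound 3 `O=C(O)CCCCc1ccc(OCc2ccc3ccccc3n2)cc1` carries 4-carboxybutyl in place of 3-carboxypropoxy on an aromatic carbon and no measured pair shows this change alone. Compound 1 also joins its chain through carbon and gives 20 nM but it differs from compound 2 elsewhere too, so only a modest shift is expected. The expected step is a 2.7-fold lower number from compound 2 to compound 3 (0.43 log units; beyond the scatter) toward a lower number and slightly beyond the scatter. The estimated value for compound 3 is 300 nM within an expected range (70 nM to 1300 nM).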

Compound 3, half-maximal inhibitory concentration: 450 nM
Compound 3: the middle estimate sits 1.5-fold (0.18 log units) below what was measured; the range from low to high includes it.
By their numbers in this assay, from the lowest: compound 1; then compounds 3 and 2 (each within the scatter of the next).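

Putting 4-carboxybutyl in place of 3-carboxypropoxy on an aromatic carbon, para to a large group, gives a 1.8-fold lower number from compound 2 to compound 3 (0.25 log units; within the scatter) in this assay, so the carbon-linked and oxygen-linked chains read alike here. The larger change lies at the chain end: 2-carboxyethyl in place of 1-((1H-tetrazol-5-yl)methyl)ethyl gives a 23-fold higher number from compound 1 to compound 3 (1.35 log units; beyond the scatter). Nothing available explains either step.

As far as these compounds go, whether the tetrazole or the methyl branch carries that large step remains open. So does how a longer chain or a terminal amide would read at this position.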